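This account rests on a few compounds, and the source may have more. Where it says the series, first, only, none or still open, it means among the compounds named here.

Measured in an ADME assay on Vero cells (Chlorocebus sabaeus) for cytotoxicity; on this read-out lower numbers stand for higher toxicity in this test and higher numbers for lower toxicity in this test:
- compound 1 `CCO/N=C(\C)CN1CCN(c2nc(=O)c3cc(C(F)(F)F)cc([N+](=O)[O-])c3s2)CC1`: > 64 ug/mL
- compound 2 `C/C(CN1CCN(c2nc(=O)c3cc(C(F)(F)F)cc([N+](=O)[O-])c3s2)CC1)=N\OCc1ccccc1`: > 64 ug/mL
- compound 3 `CON=C1CCC(CN2CCN(c3nc(=O)c4cc(C(F)(F)F)cc([N+](=O)[O-])c4s3)CC2)CC1`: > 64 ug/mL

Each of these values is a limit of this assay, not a number. Compound 3 therefore stands only at a limit, and the two other values shown for the series are limits as well; all three sit at the limit of > 64 ug/mL in this assay, at which 3 of the 3 values shown sit. Nothing in this set places one compound above another.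

Compound 4 `CCON=C1CC(CN2CCN(c3nc(=O)c4cc(C(F)(F)F)cc([N+](=O)[O-])c4s3)CC2)C1` differs from compound 3 by a group of 8 heavy atoms (6 carbon, 1 nitrogen, 1 oxygen; one four-membered non-aromatic ring of carbon only) in place of a group of 9 heavy atoms (7 carbon, 1 nitrogen, 1 oxygen; one six-membered non-aromatic ring of carbon only), on a saturated chain carbon bound to an amine nitrogen in a ring. The measured steps at this same place are a step that the two limits leave unreadable from compound 1 to compound 3 and a step that the two limits leave unreadable from compound 2 to compound 3, and the remaining step, a step that the two limits leave unreadable from compound 1 to compound 2, changes a different part of the substituent; none of the three can be read in size because both ends sit at the limit. No step beyond the scatter is therefore expected from compound 3 to compound 4, and the estimated step is a step that the limit leaves unreadable from compound 3 to compound 4. For compound 4 the expected result in this assay is 80 ug/mL, with a range from 40 ug/mL to 160 ug/mL, most probably reported again only as a limit.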

Compound 4, half-maximal cytotoxic concentration: > 64 ug/mL
Compound 4 gave a limit, no number; the forecaster's own chance of this, stated with the estimate: 85%; the middle value does not contradict the limit.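

In this assay compound 4 gives > 64 ug/mL, which is a limit and not a number. No step can be read from compound 1, compound 2 or compound 3 to compound 4, all standing at one limit: the limit of > 64 ug/mL in this assay, at which 4 of the 4 values shown sit.

The compounds shown leave open at what concentration any of them becomes cytotoxic, and whether the groups compared differ at all in this read-out.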